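Shrinking the Ring on the Ether Chain: Compound 4

The compounds below may be only part of what the source reports. "The series", "measured", "known", "first", "only" and "open" are said of these compounds alone.

Measured so far in a functional assay on CHO cells for agonist activity at Free fatty acid receptor 1 (Homo sapiens), read by FLIPR and calcium flux; a higher number here means that more compound is needed for the effect, a lower number that less compound is needed:
Compound 1, `CCOc1ccc(C)c(-c2cccc(COc3ccc(OCC(=O)O)c(F)c3)c2)c1`: 220 nM
Compound 2, `Cc1ccc(OCC(C)C)cc1-c1cccc(COc2ccc(OCC(=O)O)c(F)c2)c1`: 1450 nM
Compound 3, `Cc1ccc(OCC2CCCC2)cc1-c1cccc(COc2ccc(OCC(=O)O)c(F)c2)c1`: 490 nM

The three compounds share one core and differ only in the group carried on a saturated chain carbon bound to an oxygen on an aromatic ring. Compound 3 stands second highest of the three numbers: the step from compound 1 to compound 3 reads a 2.2-fold higher number from compound 1 to compound 3 (0.35 log units; beyond the scatter), while the step from compound 2 to compound 3 reads a 3.0-fold lower number from compound 2 to compound 3 (0.47 log units; beyond the scatter). The largest measured step is a 6.6-fold higher number from compound 1 to compound 2 (0.82 log units; beyond the scatter). Both larger groups thus cost activity against the methyl of compound 1, the five-membered ring less than the branched chain.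

Compound 4, `Cc1ccc(OCC2CCC2)cc1-c1cccc(COc2ccc(OCC(=O)O)c(F)c2)c1`, differs from compound 3 in one place: cyclobutyl in place of cyclopentyl on a saturated chain carbon bound to an oxygen on an aromatic ring. Among the compounds with values here, no measured step involves a four-membered ring, so the expectation rests on the two ring and chain steps above. A ring one carbon smaller is expected to behave much like compound 3, with a modest drift upward possible, so the expected step is a 1.2-fold higher number from compound 3 to compound 4 (0.09 log units; within the scatter). For compound 4 in this assay the estimate is 600 nM, with a range from 250 nM to 1500 nM.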

Compound 4, half-maximal effective concentration: 1530 nM
Estimate against measurement, compound 4: 2.6-fold (0.41 log units) below; measured number above the stated range.
By their numbers in this assay, from the lowest: compound 1; then compound 3; then compounds 2 and 4 (each within the scatter of the next).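

In this assay, removing one carbon from the ring is not a neutral change at this position: a 3.1-fold higher number from compound 3 to compound 4 (0.49 log units; beyond the scatter), so the cyclopentyl and cyclobutyl rings are clearly told apart. The advantage that compound 3 held over the branched chain of compound 2 is gone in compound 4, as a 1.1-fold higher number from compound 2 to compound 4 (0.02 log units; within the scatter) shows, and the distance from the methyl group of compound 1 stays large, with a 7.0-fold higher number from compound 1 to compound 4 (0.84 log units; beyond the scatter). The number therefore does not simply rise with the size of the group, since methyl gives the lowest number but the larger cyclopentyl gives a lower number than the smaller cyclobutyl, and compound 3 is the one that goes against any rule that bigger costs more.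

The compounds shown leave open whether cyclopentyl is a special case or part of a trend that continues to a cyclohexyl ring, and how a cyclopropyl ring or a tetrahydrofuranyl ring would fare on the same chain carbon. Nothing available here explains why the two rings differ.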